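This account rests on a few compounds, and the source may have more. Where it says the series, first, only, none or still open, it means among the compounds named here.

Measured so far:
compound 1, `FC(F)(F)c1ccc(-c2ccc3c(NCCCNCc4ccco4)ccnc3c2)cc1`: 32000 nM
compound 2, `COc1ccc(Oc2ccc3c(NCCCNCc4cccc(OC)c4O)ccnc3c2)cc1`: 14500 nM

In a physicochemical assay for solubility, with a stated time of 18 h, at pH 7.4 (on this read-out lower numbers stand for lower solubility and higher numbers for higher solubility), compound 1 gives the higher of the two numbers, with compound 2 sitting at a lower value, a gap that lies beyond the scatter. Compound 3, `c1coc(CNCCCNc2ccnc3cc(CC4CCCCC4)ccc23)c1`, is not yet measured in this assay. It differs from compound 1 in one place: cyclohexylmethyl in place of 4-(trifluoromethyl)phenyl on an aromatic carbon. Among the compounds with values here, no measured pair shows a step of this kind, so the size of the change is open; a small step, if any, is expected, likely upward or none beyond the scatter. For compound 3 the estimated step is a 1.3-fold higher number from compound 1 to compound 3 (0.10 log units; within the scatter). Compound 3 is therefore expected to give about 40000 nM, within a range of 15000 nM to 110000 nM.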

Compound 3, solubility: 4200 nM
For compound 3 the middle estimate is 9.5-fold (0.98 log units) above the measured one; measured number below the stated range.
By their numbers in this assay, from the lowest: compound 3; then compound 2; then compound 1.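

In this assay, cyclohexylmethyl in place of 4-(trifluoromethyl)phenyl on this aromatic carbon gives a 7.6-fold lower number from compound 1 to compound 3 (0.88 log units; beyond the scatter), which shows that the read-out depends on what this position carries. The exchange changes several things at once: an aromatic ring gives way to a non-aromatic one, and the fluorine atoms leave, so this single step cannot separate these changes. No measurement at hand accounts for the drop. On these data alone, it remains open how a plain phenyl, a morpholine or a carboxylic acid at this carbon would read out.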